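The compounds below may be only part of what the source reports. "The series", "measured", "known", "first", "only" and "open" are said of these compounds alone.

Of the compounds shown here, three in this set have been measured in a functional assay on CHO cells for antagonist activity at adenosine receptor A2b (Homo sapiens), read by 33P incorporation, with a stated time of 20 min; a lower number here means a stronger inhibitor, a higher number a weaker inhibitor. Compound 1 `Cn1c(-c2ccc(O)cc2)nc2c(NC3CCCC3)ncnc21` gives 17800 nM, the highest of the three numbers. Compound 2 `CCn1c(-c2ccccc2)nc2c(NC3CCCCC3)ncnc21` gives 9020 nM, and compound 3 `CCn1c(-c2ccccc2)nc2c(NC3CCCC3)ncnc21` gives 5790 nM. The gap between compound 1 and compound 2 lies within the scatter, whereas the gap to compound 3 lies beyond it. Among the measured compounds shown here, the only step measured between neighbours, a 1.6-fold lower number from compound 2 to compound 3 (0.19 log units; within the scatter), alters the group on a nitrogen on an aromatic ring and does not touch the group on the aromatic carbon. Compound 4 `Cn1c(-c2cccnc2)nc2c(NC3CCCC3)ncnc21` differs from compound 1 there: pyridin-3-yl in place of 4-hydroxyphenyl on an aromatic carbon. For the measured compounds named here, no measured step bears on this change, so its size is open; a step of modest size in either direction, not clearly beyond the scatter, is expected. Compound 4 is therefore estimated to give 10000 nM, between 3000 nM and 35000 nM. The expected step is thus a 1.8-fold lower number from compound 1 to compound 4 (0.25 log units; within the scatter).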

Compound 4, inhibition constant: > 30000 nM
Compound 4: a limit, no number; the forecaster's own chance of this, stated with the estimate: 10%; middle value at least 3.0-fold (0.47 log units) away from the limit.
By their numbers in this assay, from the lowest: compounds 3, 2 and 1 (each within the scatter of the next, the first and the last beyond it). At a limit, above all of these: compound 4.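

In this assay compound 4 gives > 30000 nM, which is a limit of the assay and not a number. Pyridin-3-yl in place of 4-hydroxyphenyl on an aromatic carbon gives an at least 1.6-fold higher number from compound 1 to compound 4 (0.22 log units; that floor lies within the scatter), the first step read at this position, and it brings no lower number. Only a floor is known for this step, and it is set by the limit: the limit of > 30000 nM in this assay, at which 1 of the 4 values shown sits.

The compounds shown cannot separate the loss of the hydroxyl group from the entry of the ring nitrogen. Going by these compounds, whether an aminophenyl or a carboxyphenyl group on this carbon would give a lower number than compound 1 also stays open.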